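Aryl Swap on a Triazole-Bearing Bicyclic Lactam

The source may hold more compounds than are shown below. What is called first, only, known or untested is meant among the compounds shown, and "the series" means these compounds.

Measured compounds:
compound 1 `CC1(C)[C@H]2CC[C@]1(C)N(Cc1cn(-c3ccccc3Cl)nn1)C(=O)C2` — 60 nM
compound 2 `CC1(C)[C@H]2CC[C@]1(C)N(Cc1cn(-c3ccccc3O)nn1)C(=O)C2` — 120 nM

Two compounds share a bicyclic lactam core joined through a methylene to a triazole that carries an aromatic ring. In a functional assay on HepG2 cells (Homo sapiens) for inhibition, read by MTT assay, with a stated time of 24 h (a lower number here means a stronger inhibitor, a higher number a weaker inhibitor), compound 1 gives 60 nM and compound 2 gives 120 nM. Compound 2 has the higher of the two numbers, but the step of a 2.0-fold higher number from compound 1 to compound 2 (0.30 log units; within the scatter) stays inside the usual scatter, so the two values are not distinguishable.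

Compound 3 `Cc1cccc(-n2cc(CN3C(=O)C[C@@H]4CC[C@@]3(C)C4(C)C)nn2)c1` has not yet been measured in this assay. It differs from compound 2 by 3-methylphenyl in place of 2-hydroxyphenyl on an aromatic nitrogen.

For the measured compounds named here, only the step from compound 1 to compound 2 bears on this change: it also replaced a substituent on the phenyl ring attached to the triazole, and it was a 2.0-fold higher number from compound 1 to compound 2 (0.30 log units; within the scatter), within the scatter. Going by the values given here, no measured step speaks to a methyl on the phenyl ring or to removing the hydroxy outright. On that basis compound 3 is expected to give a value close to those already seen, with the step of a 1.5-fold lower number from compound 2 to compound 3 (0.18 log units; within the scatter) likely not exceeding the scatter. Compound 3 is therefore estimated at 80 nM, with a range of 30 nM to 250 nM.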

Compound 3, half-maximal inhibitory concentration: 300 nM
The estimate for compound 3 lay 3.8-fold (0.57 log units) below the measured number, and the stated range ends below it.
By their numbers in this assay, from the lowest: compounds 1 and 2 (each within the scatter of the next); then compound 3.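

In this assay, the aryl group on the triazole nitrogen turns out to matter: a 2.5-fold higher number from compound 2 to compound 3 (0.40 log units; beyond the scatter) and a 5.0-fold higher number from compound 1 to compound 3 (0.70 log units; beyond the scatter), so compound 3 is a weaker inhibitor than both compound 1 and compound 2, whereas the earlier swap between chloro and hydroxy stayed within the scatter. The size of the group does not account for this on the counts available, since 2-hydroxyphenyl and 3-methylphenyl each have 7 heavy atoms, although the two differ in that 3-methylphenyl has no hydrogen-bond donor or acceptor and carries its substituent at a different ring position. No measurement here explains the shift, and nothing given bears on why the number rises.

The compounds shown leave open whether the loss follows the ring position of the substituent or its kind, a question that 2-methylphenyl and 3-hydroxyphenyl would separate, since each keeps one of these and alters the other. They also leave open how the plain phenyl ring, or a ring carrying an amine or a carboxylic acid, would compare with these three aryl groups.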